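Four-position substituent on the chromenone core: large amide versus hydroxymethyl

The compounds below may be only part of what the source reports. "The series", "measured", "known", "first", "only" and "open" are said of these compounds alone.

Compound 3 `O=C(COc1cc(=O)oc2cc(OCc3cccc(Cl)c3)ccc12)N1CCCCC1` gives 38900 nM in an assay on isolated protein (strain Sprague-Dawley) for inhibition of Amine oxidase [flavin-containing] B (Rattus norvegicus), read by spectrophotometry, with a stated time of 5 min (a lower number here means a stronger inhibitor, a higher number a weaker inhibitor), the highest of the three numbers in hand. Its nearest neighbour is compound 1 `O=c1cc(O)c2ccc(OCc3cccc(Br)c3)cc2o1` at 490 nM; furthest is compound 2 `COc1cc(=O)oc2cc(OCc3cccc(Br)c3)ccc12` at 5.75 nM. Among the measured compounds shown here, the only single-point step measured, an 85-fold lower number from compound 1 to compound 2 (1.93 log units; beyond the scatter), concerns the oxygen at this same ring position and shows how strongly the series reacts to what sits there.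

Compound 4 `O=c1cc(CO)c2ccc(OCc3cccc(Cl)c3)cc2o1` is the next entry. The change from compound 3 is hydroxymethyl in place of ((piperidin-1-yl)carbonyl)methoxy on an aromatic carbon. For the measured compounds named here, no measured step covers this exact exchange. Compound 1, carrying a single heavy atom at the same aromatic carbon and a bromine rather than a chlorine on the benzyl ring, stands far below compound 3; the ((piperidin-1-yl)carbonyl)methoxy group of compound 3 is thus the feature paired with the weakest number seen. The hydroxymethyl of compound 4 is closer in size to the group of compound 1, so a large drop in the number is expected, a 49-fold lower number from compound 3 to compound 4 (1.69 log units; beyond the scatter), though a return to the level of compound 2 is not.

Compound 4 is estimated at 800 nM, with a range from 100 nM to 6000 nM.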

Compound 4, half-maximal inhibitory concentration: 5.25 nM
Compound 4: middle estimate off by 150-fold (2.18 log units), on the high side; the whole stated range lies above it.
By their numbers in this assay, from the lowest: compounds 4 and 2 (each within the scatter of the next); then compound 1; then compound 3.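

At the aromatic carbon opposite the ring oxygen, the exchange of ((piperidin-1-yl)carbonyl)methoxy for hydroxymethyl in this assay gives a 7400-fold lower number from compound 3 to compound 4 (3.87 log units; beyond the scatter), so a small group bearing a hydroxyl on carbon is compatible with a very low number at this position. This step is larger than the earlier one at the same position, an 85-fold lower number from compound 1 to compound 2 (1.93 log units; beyond the scatter), and shows that the range of the series at this carbon reaches far beyond what that pair indicated. The exchange alters heavy-atom count, ring, amide and hydrogen-bond donor count together, and no measurement offered here explains the size of the step.

Going by these compounds, it remains open which of these features carries the difference, and at what size the number begins to rise. A hydroxyethyl chain, an aminomethyl group or a carboxylic acid at this carbon would help separate these features.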